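Aryl swap on the triazole nitrogen: compound 3 to compound 4

The source may report more compounds than this note shows. Statements on the series, on what has been measured and on what is new or still open speak of the compounds shown alone.

Working notes on a series that shares one core and varies the aryl group on the triazole nitrogen and the amine at the chain end. Compound 1 `COc1cc2c(Oc3ccc(NC(=O)c4nnn(-c5ccc(F)c(F)c5)c4C(F)(F)F)cc3F)ccnc2cc1OCCCN1CCCCC1` in a functional assay on MKN-45 cells (Homo sapiens) for cytotoxicity, read by MTT assay, with a stated time of 72 h (a higher number here means a weaker inhibitor, a lower number a stronger inhibitor), gives 90 nM. Compound 2 `COc1cc2c(Oc3ccc(NC(=O)c4nnn(-c5ccc(C)cc5)c4C(F)(F)F)cc3F)ccnc2cc1OCCCN1CCC(C)CC1` gives 140 nM. Compound 3 `COc1cc2c(Oc3ccc(NC(=O)c4nnn(-c5ccccc5C(F)(F)F)c4C(F)(F)F)cc3F)ccnc2cc1OCCCN1CCC(C)CC1` gives 100 nM, the second highest of the three numbers, separated from compound 1 and from compound 2 by gaps that both lie within the scatter. For the measured compounds named here, the one measured step that changes the aryl group on the triazole nitrogen, a 1.4-fold lower number from compound 2 to compound 3 (0.15 log units; within the scatter), stays within the scatter.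

Compound 4 `COc1cc2c(Oc3ccc(NC(=O)c4nnn(-c5ccc(F)c(F)c5)c4C(F)(F)F)cc3F)ccnc2cc1OCCCN1CCC(C)CC1` is not yet measured. It differs from compound 3 by 3,4-difluorophenyl in place of 2-(trifluoromethyl)phenyl on an aromatic nitrogen. Going by the values given here, the step from compound 2 to compound 3 is the only measured step of this kind and it was within the scatter, so no shift beyond the scatter is expected here. Compound 1 carries the same 3,4-difluorophenyl group as compound 4 and differs from it only in the amine; its value and that of compound 3 lie close together, which supports the same reading. Compound 4 is therefore expected to give about 95 nM, between 50 nM and 190 nM. The expected step of a 1.1-fold lower number from compound 3 to compound 4 (0.02 log units; within the scatter) is within the scatter.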

Compound 4, half-maximal inhibitory concentration: 50 nM
The estimate for compound 4 lay 1.9-fold (0.28 log units) above the measured number; the range from low to high includes it.
By their numbers in this assay, from the lowest: compounds 4, 1, 3 and 2 (each within the scatter of the next, the first and the last beyond it).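

In this assay, the aryl group on the aromatic nitrogen now gives its first step beyond the scatter, though a modest one: a 2.8-fold lower number from compound 2 to compound 4 (0.45 log units; beyond the scatter), with 3,4-difluorophenyl in place of 4-methylphenyl, whereas the earlier step at this position, a 1.4-fold lower number from compound 2 to compound 3 (0.15 log units; within the scatter), did not separate its two groups. The other two new steps do not extend this, since a 2.0-fold lower number from compound 3 to compound 4 (0.30 log units; within the scatter) leaves 3,4-difluorophenyl and 2-(trifluoromethyl)phenyl unresolved, and a 1.8-fold lower number from compound 1 to compound 4 (0.26 log units; within the scatter) shows that methyl in place of hydrogen on a saturated ring carbon also stays within the scatter. No measurement at hand explains why the aryl change separates one pair of compounds and not the other.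

Going by these compounds, only 3,4-difluorophenyl appears here with both amines, so it remains open whether the small step for the added methyl would hold with 4-methylphenyl or 2-(trifluoromethyl)phenyl on the aromatic nitrogen. Also open, on these data alone, is how the series would respond to an aryl group with a ring nitrogen, such as pyridyl, on that aromatic nitrogen, or to morpholine at the chain end.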